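Methoxy in place of hydrogen: cytotoxicity notes on the series

The source may hold more compounds than are shown below. What is called first, only, known or untested is meant among the compounds shown, and "the series" means these compounds.

Measured compounds:
compound 1, `COc1ccc(-n2ncn(Cc3cn(Cc4cc5cc(Cl)ccc5nc4Cl)nn3)c2=O)cc1`, 1060 ug/mL
compound 2, `Cc1cccc2cc(Cn3cc(Cn4cnn(-c5ccccc5)c4=O)nn3)c(Cl)nc12`, 729 ug/mL
compound 3, `O=c1n(Cc2cn(Cc3cc4cc(Cl)ccc4nc3Cl)nn2)cnn1-c1ccccc1`, 459 ug/mL

In an ADME assay on HEK293 cells (Homo sapiens) for cytotoxicity, read by MTT assay (a lower number here means a stronger inhibitor, a higher number a weaker inhibitor), the three measured compounds lie within a narrow band. Compound 2 stands second highest of the three; its gap to compound 1 and its gap to compound 3 both lie within the scatter, so no order is claimed for those pairs. Among the compounds with values here, the one change that can be counted between measured compounds is methoxy in place of hydrogen on an aromatic carbon, and it made the step of a 2.3-fold higher number from compound 3 to compound 1 (0.36 log units; beyond the scatter).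

The difference between the core of compound 2 and the core of compound 3 is not broken down here.

Compound 4, `COc1ccc(-n2ncn(Cc3cn(Cc4cc5cccc(C)c5nc4Cl)nn3)c2=O)cc1`, is not yet measured. It differs from compound 2 by methoxy in place of hydrogen on an aromatic carbon, which is the same change as from compound 3 to compound 1, with the place described in identical words. Because the earlier pair shows a 2.3-fold higher number from compound 3 to compound 1 (0.36 log units; beyond the scatter), the expectation for compound 4 rests on carrying that step over to compound 2, tempered by the fact that it is a single prior instance on a core that differs in ways not broken down here. For compound 4 the expected step is a 1.9-fold higher number from compound 2 to compound 4 (0.28 log units; within the scatter). Compound 4 is therefore estimated at 1400 ug/mL, with an expected range from 700 ug/mL to 2800 ug/mL.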

Compound 4, half-maximal inhibitory concentration: 586 ug/mL
Compound 4: the middle estimate sits 2.4-fold (0.38 log units) above what was measured, and the stated range ends above it.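

In this assay, methoxy in place of hydrogen on an aromatic carbon, para to a large group, gives a 1.2-fold lower number from compound 2 to compound 4 (0.09 log units; within the scatter), so no effect of phenyl to 4-methoxyphenyl can be read on the core of compound 2. The step seen on the core of compound 3 therefore does not carry over in size to the core of compound 2, and the two steps must be read as different: the same change on two cores in this assay, a 2.3-fold higher number (0.36 log units; beyond the scatter) from compound 3 to compound 1 and a 1.2-fold lower number (0.09 log units; within the scatter) from compound 2 to compound 4, 2.9-fold (0.46 log units) apart, beyond the scatter of two such steps This shows that, across these two cores, the outcome of the change depends on the core, but it rests on a single pair per core and does not show which feature of the cores goes with the difference, nor what the change would do on any third core.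

The compounds shown carry only hydrogen or methoxy at this place on the phenyl ring, so the outcome with an amine, a carboxylic acid or a longer alkoxy chain there remains open on both cores. Also open is how the chlorine and methyl groups on the two cores each bear on the step, as the compounds shown do not separate them.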